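This account rests on a few compounds, and the source may have more. Where it says the series, first, only, none or still open, it means among the compounds named here.

Compound 1 `Nc1scc(CN2CCN(c3ccc(Cl)cc3Cl)CC2)c1C(=O)c1ccc(Cl)cc1` stands highest of the three compounds measured in a functional assay on CHO cells with adenosine receptor A1 (Homo sapiens) as the target, read by cAMP accumulation and immunoassay, with a stated time of 6 min, tested at 0.01 uM (a higher number here means a weaker effect of the compound at the concentration tested, a lower number a stronger effect), where compound 1 gives 2%. Compound 2 `Nc1scc(CN2CCN(c3ccccc3C(F)(F)F)CC2)c1C(=O)c1ccc(Cl)cc1` gives 0% in this assay, and compound 3 `Nc1scc(CN2CCN(c3ccc(OC(F)(F)F)cc3)CC2)c1C(=O)c1ccc(Cl)cc1` gives 0%. The steps of a number 2 percentage points lower from compound 1 to compound 2 (within the scatter) and a number 2 percentage points lower from compound 1 to compound 3 (within the scatter) both lie within the scatter, as does no change at the digits printed from compound 2 to compound 3 (within the scatter). Compound 4 `Nc1scc(CN2CCN(c3cc(F)cc(F)c3)CC2)c1C(=O)c1ccc(Cl)cc1` differs from compound 1 by 3,5-difluorophenyl in place of 2,4-dichlorophenyl on an amine nitrogen in a ring. The two measured steps that replace the same group on the ring nitrogen both moved the read-out by amounts within the scatter, so the expected step here is a number 1 percentage points lower from compound 1 to compound 4 (within the scatter), which is not expected to exceed the scatter either. Compound 4 is therefore estimated at 1%, with a range from -8% to 10%.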

Compound 4, a percentage reported as activity, at one concentration (the size of the read-out at that concentration, not a potency): -13%
Beside the measured number, compound 4's estimate is 14 percentage points above it; the whole stated range lies above it.
By their numbers in this assay, from the lowest: compound 4; then compounds 2, 3 and 1 (each within the scatter of the next).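

In this assay, going by these compounds alone, the group on the amine nitrogen in a ring moved the read-out beyond the scatter, which no replacement among the earlier compounds had done: 3,5-difluorophenyl gives a number 15 percentage points lower from compound 1 to compound 4 (beyond the scatter), a number 13 percentage points lower from compound 2 to compound 4 (beyond the scatter) and a number 13 percentage points lower from compound 3 to compound 4 (beyond the scatter). All three steps are modest and point towards a stronger effect at the concentration tested. Nothing measured here accounts for this difference.

Going by these compounds, it remains open whether a phenyl bearing a single fluorine, or a methoxy group or an amine in place of the fluorines, would give a step of this size.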